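Predicting a nitrile-for-fluorine swap in a hydrolase inhibitor

The source may report more compounds than this note shows. Statements on the series, on what has been measured and on what is new or still open speak of the compounds shown alone.

This small set concerns inhibitors of a human deubiquitinating enzyme, characterised in an assay on Sf21 cells for inhibition of ubiquitin carboxyl-terminal hydrolase 7 (Homo sapiens), read by spectrophotometry, with stated times of 30 min and 2 h; on this read-out lower numbers stand for stronger inhibition and higher numbers for weaker inhibition. Within the data shown here, only one compound in the set has a number: compound 1 `COC(=O)c1ccc(N2CCC(O)(Cn3cnc4c(Br)n(C)nc4c3=O)CC2)c(Cl)c1`, which gives 157 nM. Compound 2 `O=c1c2cnn(-c3ccc(F)cc3)c2ncn1CC1(O)CCN(Cc2ccccc2)CC1` belongs to a different sub-series, sharing the hydroxypiperidine and the pyrazolopyrimidinone core but carrying a 4-fluorophenyl on the core and a benzyl on the ring amine; in this assay compound 2 is recorded as "not determined" (no result reported). Among the measured compounds shown here, compound 3 `O=c1c2cnn(-c3ccc(F)cc3)c2ncn1CC1(O)CCN(Cc2ccc(F)cc2)CC1` is the same scaffold with a 4-fluorobenzyl on the ring amine, and in this assay compound 3 likewise stands at "not determined" (no result reported), so there is no single number for it, and no step to any measured neighbour can be computed.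

Compound 4 `N#Cc1ccccc1CN1CCC(O)(Cn2cnc3c(cnn3-c3ccc(F)cc3)c2=O)CC1` is reached from compound 3 by one change: 2-cyanophenyl in place of 4-fluorophenyl on a saturated chain carbon bound to an amine nitrogen in a ring. For the measured compounds named here, since compound 3 carries no number, the size and direction of this step cannot be read from the data, and the only anchor is compound 1 at 157 nM, which is built on a different core decoration.

On that basis the potency of compound 4 in this assay is expected to be roughly 100 nM, with a plausible range from 20 nM to 600 nM.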

Compound 4, half-maximal inhibitory concentration: 8100 nM
For compound 4 the middle estimate is 81-fold (1.91 log units) below the measured one; the measured number lies above the stated range.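

Among these compounds, compound 4 now has a value in this assay, but compound 3 carries no single number, so no step between compound 3 and compound 4 can be read. The compounds shown leave open how the swap from 4-fluorobenzyl to 2-cyanobenzyl shifts inhibition. Nothing shown here bears on why compound 4 gives this result.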